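The source may hold more compounds than are shown below. What is called first, only, known or untested is meant among the compounds shown, and "the series" means these compounds.

Compound 1 `ClCc1cccc(Cn2cnc3c(Cl)ncnc32)c1` was tested in a functional assay on CCRF-CEM cells (Homo sapiens) for cytotoxicity, read by sulforhodamine B assay, with a stated time of 48 h (on this read-out higher numbers stand for lower toxicity in this test and lower numbers for higher toxicity in this test), where compound 1 gives 7620 nM. Of the two numbers available in this assay, compound 1 has the highest; the nearest is compound 2 `ClCc1cccc(Cn2cnc3nc(Cl)nc(Cl)c32)c1`, which in this assay gives 5490 nM, a gap that lies within the scatter, so the two numbers show no difference between compound 1 and compound 2 that can be read as an order.

The next compound, compound 3 `Nc1nc(Cl)c2ncn(Cc3cccc(CCl)c3)c2n1`, is reached from compound 1 by a single change: amino in place of hydrogen on an aromatic carbon, an amino in place of hydrogen on an aromatic carbon. For the measured compounds named here, no pair of measured compounds shows what such a change does in this assay, so there is nothing to lean on beyond the two numbers given.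

In the absence of a measured step of this kind, the expectation for compound 3 is a step of a 1.2-fold lower number from compound 1 to compound 3 (0.07 log units; within the scatter) of no clear size, in neither direction beyond the scatter. Compound 3 is therefore expected to give an estimated 6500 nM in this assay, within a range from 2500 nM to 17000 nM.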

Compound 3, concentration lethal to 50% of the cells: > 100000 nM
Compound 3: only a limit was reported (the forecaster's own chance of this, stated with the estimate: 5%); middle value at least 15-fold (1.18 log units) away from the limit.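

For the compounds shown here, until this result, no measured step showed what a change at this position does: the numbers for compound 1 and compound 2 lay within the scatter of each other, and no pair of compounds differed in one place. In this assay, amino in place of hydrogen on the aromatic carbon between two ring nitrogen atoms gives an at least 13-fold higher number from compound 1 to compound 3 (1.11 log units; beyond the scatter), so this one small change is enough to move the compound far toward lower toxicity in this test, well beyond the scatter. For compound 3 the reported figure is a limit and not a number, so the step has a minimum size but no known full size: the limit of > 100000 nM in this assay, at which 1 of the 3 values shown sits.

Going by these compounds, whether the step is specific to amino remains open, since a methylamino or a hydroxyl group at this same position would be needed to show if other groups behave alike. Also open, on these data alone, is whether amino would do the same alongside other parts of the molecule, for example with the chloromethyl group on the benzyl ring replaced by a methyl group.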